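Replacing cyano with trifluoromethyl in compound 1

The source may hold more compounds than are shown below. What is called first, only, known or untested is meant among the compounds shown, and "the series" means these compounds.

In a functional assay on KG-1 cells (Homo sapiens) for cytotoxicity, read by luminescence and CellTiter-Glo, with a stated time of 3 days (on this read-out lower numbers stand for stronger inhibition and higher numbers for weaker inhibition), compound 1 `N#Cc1cccc(NC(=O)c2cc(F)ccc2O)c1` gives the highest of three numbers (9100 nM). Compound 2 `O=C(Nc1ccc(OC(F)(F)F)cc1)c1cc(F)ccc1O` gives a much lower number (780 nM), and compound 3 `O=C(Nc1ccc(OC(F)(F)F)c(Cl)c1)c1cc(F)ccc1O` lower again (370 nM). Both gaps from compound 1 lie beyond the scatter.

Compound 4 `O=C(Nc1cccc(C(F)(F)F)c1)c1cc(F)ccc1O` keeps the core of compound 1 and carries trifluoromethyl in place of cyano on an aromatic carbon. Among the measured compounds shown here, no measured step makes this exchange. For the measured compounds named here, the only single-site step available is modest but beyond the scatter (a 2.1-fold lower number from compound 2 to compound 3 (0.32 log units; beyond the scatter)), and it puts chloro in place of hydrogen on an aromatic carbon, so it bears on the question only indirectly. The closer guide is compound 2 (780 nM), which has no cyano and carries trifluoromethoxy, a group that resembles the incoming one by name but sits differently. Its value suggests that losing cyano may go with a much lower number, though the data do not separate the effects of the two changes. What is expected in this assay is therefore a large step beyond the scatter, a 6.1-fold lower number from compound 1 to compound 4 (0.78 log units; beyond the scatter) as the estimated change. Compound 4 is estimated at 1500 nM (expected range 500 nM to 4500 nM).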

Compound 4, half-maximal inhibitory concentration: 1010 nM
The estimate for compound 4 lay 1.5-fold (0.17 log units) above the measured number, within the range that was stated.
By their numbers in this assay, from the lowest: compound 3; then compounds 2 and 4 (each within the scatter of the next); then compound 1.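

In this assay, the exchange of cyano for trifluoromethyl on this aromatic carbon, meta to a large group, is a single-site change on the core of compound 1, and it gives a 9.0-fold lower number from compound 1 to compound 4 (0.95 log units; beyond the scatter). The earlier compounds shown here could only hint at this, since none of them changed cyano alone, whereas this pair shows that the exchange by itself moves the number beyond the scatter, with the rest of the structure held fixed. Nothing shown explains the step through a measured property of either group.

This single pair cannot tell whether the step goes with the hydrogen-bond acceptor that leaves with cyano or with the greater number of heavy atoms that enters with trifluoromethyl, and a single exchange at one position gives no trend across groups. The compounds shown also leave open how an amine, a carboxylic acid or a simple methyl group would read at this position, and whether chloro in place of hydrogen would give a similar step on the core of compound 4.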